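From an Ethyl Amine to a Cyclopropyl Amide

A few compounds are considered here, and "the series" means these few. Any claim that something is new, unique, unknown or untested is made for them only; others in the source may bear on it.

Measured compounds:
Compound 1 `Cc1cccc(C#Cc2nc3c(s2)C(=O)NCC3)c1`: in an assay on HEK293 cells for negative allosteric modulation of metabotropic glutamate receptor 5 (Homo sapiens), read by FLIPR, with a stated time of 1 h (a lower number here means a stronger inhibitor, a higher number a weaker inhibitor), compound 1 reaches only the assay's limit of > 10000 nM.
Compound 2 `CCN1CCc2nc(C#Cc3ccccc3)sc2C1`: in this assay compound 2 gives 1200 nM.

Within the data shown here, compound 2 therefore holds the only actual number in this set, the other entry being a limit (the limit of > 10000 nM in this assay, at which 1 of the 2 values shown sits). Compound 3 `CC1CC1C(=O)N1CCc2nc(C#Cc3ccccc3)sc2C1` departs from compound 2 by (2-methylcyclopropyl)carbonyl in place of ethyl on an amine nitrogen in a ring. Among the measured compounds shown here, no measured step covers such an exchange. The step from compound 2 to compound 3 is expected to bring a gain, a 4.8-fold lower number from compound 2 to compound 3 (0.68 log units; beyond the scatter). Compound 3 is accordingly estimated at 250 nM, between 50 nM and 1500 nM.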

Compound 3, half-maximal inhibitory concentration: > 10000 nM
Compound 3: a limit, no number (the forecaster's own chance of this, stated with the estimate: 5%); at least 40-fold (1.60 log units) between middle value and limit.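

Among these compounds, at the amine nitrogen in the ring, (2-methylcyclopropyl)carbonyl in place of ethyl gives the first readable step in this set, and it is a loss: in this assay the change brings an at least 8.3-fold higher number from compound 2 to compound 3 (0.92 log units; beyond the scatter). On these data alone, compound 3 gives only a limit, > 10000 nM, so this step sets a minimum and its full size remains unknown. The set now rests largely on such limits: the limit of > 10000 nM in this assay, at which 2 of the 3 values shown sit.

As far as these compounds go, it remains open whether a plain acetyl or a cyclopropylcarbonyl on this nitrogen would fare better. Also open, from the compounds shown here alone, is whether a methyl or a longer alkyl chain there would match or surpass compound 2.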